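The compounds below may be only part of what the source reports. "The series", "measured", "known", "first", "only" and "open" are said of these compounds alone.

Measured compounds:
- compound 1, `Cc1ccc(-c2c(C)nn(-c3nc(-c4ccc(Cl)c(Cl)c4)c(SC(C)C)s3)c2C(=O)O)cc1`: 3800 nM
- compound 2, `Cc1nn(-c2nc(-c3ccc(Cl)c(Cl)c3)c(SC(C)C)s2)c(C(=O)O)c1-c1ccccc1Cl`: 13100 nM

Both compounds share one core and differ only in the aryl group attached to it. In a functional assay on BJAB cells (Homo sapiens) for antiproliferative activity, with a stated time of 4 days (on this read-out lower numbers stand for an effect already at smaller amounts and higher numbers for an effect only at larger amounts of compound), compound 1 gives 3800 nM, while compound 2 gives 13100 nM. Within the data shown here, the single step that has been measured, a 3.4-fold higher number from compound 1 to compound 2 (0.54 log units; beyond the scatter), shows that exchanging the aryl group can shift the number by a modest amount. Among the two numbers shown, compound 2 stands at the higher one, with compound 1 as its only neighbour.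

Compound 3, `Cc1nn(-c2nc(-c3ccc(Cl)c(Cl)c3)c(SC(C)C)s2)c(C(=O)O)c1-c1ccccc1C(F)(F)F`, is not yet measured. It differs from compound 2 by trifluoromethyl in place of chloro on an aromatic carbon; cut one bond further out this reads 2-chlorophenyl to 2-(trifluoromethyl)phenyl, on an aromatic carbon of a six-membered aromatic ring of carbon only, ortho to a large group. Among the measured compounds shown here, no measured step shows this particular exchange; the only step available concerns a different change of the same aryl group. The expectation for compound 3 is therefore cautious: a step of a 1.1-fold higher number from compound 2 to compound 3 (0.06 log units; within the scatter) in this assay, possibly none beyond the scatter. Compound 3 is estimated at 15000 nM, within 5000 nM to 45000 nM.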

Compound 3, half-maximal effective concentration: 5200 nM
Beside the measured number, compound 3's estimate is 2.9-fold (0.46 log units) above it; measured number inside the range.
By their numbers in this assay, from the lowest: compounds 1 and 3 (each within the scatter of the next); then compound 2.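

In this assay, going from 2-chlorophenyl to 2-(trifluoromethyl)phenyl gives a 2.5-fold lower number from compound 2 to compound 3 (0.40 log units; beyond the scatter), so the number responds to which group sits on this aromatic carbon, and not just to which kind of aryl group is attached. Among these compounds, the one earlier step compared two differently substituted aryl groups, whereas this one changes a single group while its place on the ring stays the same, and the comparison with 4-methylphenyl gives a 1.4-fold higher number from compound 1 to compound 3 (0.14 log units; within the scatter), a step within the usual scatter, so these two compounds cannot be told apart here. A group in this place therefore does not bring the higher number by itself: compound 3 goes against that reading, and among these three compounds only compound 2 stands apart from the others.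

No measurement at hand gives a reason for either step. Still open, from the compounds shown here alone, is how this place would respond to a nitrile, an amine or a methoxy group, and whether the same ordering would hold if the carboxylic acid on the shared core were replaced by an amide.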